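This account rests on a few compounds, and the source may have more. Where it says the series, first, only, none or still open, it means among the compounds named here.

Measured so far:
- compound 1 `CC1=C([Se]CC(OC(=O)[C@@H](CO)NC(=O)OC(C)(C)C)C(=O)NCCCCCC(=O)OCc2ccccc2)C(=O)c2ccccc2C1=O`: 5000 nM
- compound 2 `CC1=C([Se]CC(OC(=O)[C@@H](CSSC(C)(C)C)NC(=O)C(C)(C)C)C(=O)NCCCCCC(=O)OCc2ccccc2)C(=O)c2ccccc2C1=O`: 13000 nM

Both numbers come from a functional assay on A498 cells (Homo sapiens) for cytotoxicity, read by MTT assay, with a stated time of 24 h; on this read-out lower numbers stand for stronger inhibition and higher numbers for weaker inhibition. Compound 1 holds the lower of the two, and its gap to compound 2, which gives 13000 nM in this assay, lies beyond the usual scatter of repeated measurements. Within the data shown here, no pair of measured compounds differs in a single place, so there is no measured step to lean on.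

Compound 3 `CC1=C([Se]CC(OC(=O)CNC(=O)OC(C)(C)C)C(=O)NCCCCCC(=O)OCc2ccccc2)C(=O)c2ccccc2C1=O` is not yet measured in this assay. Against compound 1 the change is hydrogen in place of hydroxymethyl on a saturated chain carbon bound to an amide-type nitrogen and a carbonyl carbon. The rest of the molecule, the shared core and the chain ending in the benzyl ester, is unchanged. Among the measured compounds shown here, with no measured step of the same kind in the set, the expected step is a 1.3-fold higher number from compound 1 to compound 3 (0.11 log units; within the scatter), a small shift toward a higher number that is not expected to exceed the scatter. Compound 3 is estimated at 6500 nM in this assay, with a range from 3000 nM to 14000 nM.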

Compound 3, half-maximal inhibitory concentration: 7000 nM
Estimate against measurement, compound 3: 1.1-fold (0.03 log units) below; low and high end bracket the measured number.
By their numbers in this assay, from the lowest: compounds 1, 3 and 2 (each within the scatter of the next, the first and the last beyond it).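

In this assay, among these compounds, hydrogen in place of hydroxymethyl on a saturated chain carbon bound to an amide-type nitrogen and a carbonyl carbon gives a 1.4-fold higher number from compound 1 to compound 3 (0.15 log units; within the scatter), the first single-place step. At this position, then, the hydroxymethyl group can be replaced by hydrogen without a shift that can be told from the scatter, so the value of compound 1 does not rest on that group in this read-out. No measured evidence bears on why this step is so small.

The compounds shown compare only hydrogen and hydroxymethyl on this carbon, so it remains open whether an aminomethyl group, a carboxylic acid or a longer chain such as hydroxyethyl would be tolerated as well. On these data alone, the effect of single changes elsewhere, such as at the tert-butoxycarbonyl group or the benzyl ester, also remains open.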